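Hydroxy in Place of Carboxy on a Saturated Ring Carbon

A few compounds are considered here, and "the series" means these few. Any claim that something is new, unique, unknown or untested is made for them only; others in the source may bear on it.

Compound 2 `O=C(O)C1CCN(c2nc(-c3cc(F)c(Cl)cc3F)nc3c2CS(=O)(=O)C3)CC1` carries a carboxy group on a saturated ring carbon of the shared core. In a functional assay on the whole organism (blood, strain ICR) with Mus musculus as the target, in the glucose tolerance test, with a stated time of 30 min (a higher number here means that more compound is needed for the effect, a lower number that less compound is needed), compound 2 reaches only the limit > 3 mg/kg, so where it stands among the numbers is known as a bound alone. Within the data shown here, the one measured step that bears on the matter comes from compound 1 `NC(=O)CC1CCN(c2nc(-c3cc(F)c(Cl)cc3F)nc3c2CS(=O)(=O)C3)CC1`, which in this assay gives 0.1 mg/kg. The change an at least 30-fold higher number from compound 1 to compound 2 (1.47 log units; beyond the scatter) is large, and the limit of > 3 mg/kg in this assay, at which 1 of the 2 values shown sits, marks how far it was followed. Compound 3 `O=S1(=O)Cc2nc(-c3cc(F)c(Cl)cc3F)nc(N3CCC(O)CC3)c2C1` differs from compound 2 by hydroxy in place of carboxy on a saturated ring carbon. Because the large step of an at least 30-fold higher number from compound 1 to compound 2 (1.47 log units; beyond the scatter) came with the carboxy group entering, compound 3 is expected to recover much of that loss once the same group leaves, though one step cannot say how far. The step of an at least 6.0-fold lower number from compound 2 to compound 3 (0.77 log units; beyond the scatter) is therefore estimated as a gain. Compound 3 is expected at 0.5 mg/kg in this assay, between 0.1 mg/kg and 3 mg/kg.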

Compound 3, minimum effective dose: 1 mg/kg
Compound 3: the middle estimate sits 2.0-fold (0.30 log units) below what was measured; measured number inside the range.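

In this assay, among these compounds, hydroxy in place of carboxy on this saturated ring carbon gives an at least 3.0-fold lower number from compound 2 to compound 3 (0.47 log units; beyond the scatter), so the position tolerates a change away from carboxy with a real gain, and carbamoylmethyl is not the only group that improves on carboxy here. Hydroxy still falls short of carbamoylmethyl, with a 10-fold higher number from compound 1 to compound 3 (1.00 log units; beyond the scatter), so the three groups at this position are separated from one another and the gain stops short of compound 1. Compound 2 stands only as a limit, and the first of these steps therefore gives a minimum size: the limit of > 3 mg/kg in this assay, at which 1 of the 3 values shown sits.

The compounds shown do not separate the role of the carbamoyl end of the chain from that of its length. A hydroxymethyl group, a primary amine or a carbamoyl group set directly on this ring carbon would bear on that question.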